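Notes on the step from compound 3 to compound 4

This account rests on a few compounds, and the source may have more. Where it says the series, first, only, none or still open, it means among the compounds named here.

Measured in an ADME assay on MT4 cells (Homo sapiens) for activation, read by MTT assay; on this read-out higher numbers stand for lower toxicity in this test and lower numbers for higher toxicity in this test:
- compound 1 `CCCSc1nc(C(C)c2c(F)cccc2Cl)c(C)c(=O)[nH]1`: > 1500 nM
- compound 2 `CCCCSc1nc(C(C)c2c(F)cccc2Cl)c(C)c(=O)[nH]1`: > 1500 nM
- compound 3 `Cc1c(C(C)c2c(F)cccc2Cl)nc(SC2CCCC2)[nH]c1=O`: > 15000 nM

Each of these readings is a limit and not a number, so no order can be drawn among the three compounds.

The position of compound 3 is known only as a limit, > 15000 nM. Compound 4 `CCc1c(C(C)c2c(F)cccc2Cl)nc(SC2CCCC2)[nH]c1=O` differs from it by methyl in place of hydrogen on a saturated chain carbon bound to an aromatic carbon, which reads as methyl to ethyl. The nearest measured change in kind is a step that the two limits leave unreadable from compound 1 to compound 2, also a methyl in place of hydrogen on a saturated chain carbon, though in another place. The other two steps, a step that the two limits leave unreadable from compound 1 to compound 3 and a step that the two limits leave unreadable from compound 2 to compound 3, concern the group on the sulfur. None of the three gives a size to carry over, and none suggests a direction. The estimated step is a number no higher from compound 3 to compound 4 (the limit leaves the size open), so no shift beyond the usual scatter is expected in this assay. For compound 4 the estimated value is 15000 nM, with an expected range from 3000 nM to 50000 nM.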

Compound 4, half-maximal cytotoxic concentration: > 3000 nM
Compound 4 was reported as a limit; the forecaster's own chance of this, stated with the estimate: 80%; the middle value lies beyond the limit too.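

For the compounds shown here, compound 3 and compound 4 are both reported as limits and not as numbers, so no step between them can be read. The compounds shown leave open whether methyl to ethyl shifts the reading in this assay at all, and in which direction.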